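Carboxylic Acid in Place of Trifluoromethyl on the Shared Core

This account rests on a few compounds, and the source may have more. Where it says the series, first, only, none or still open, it means among the compounds named here.

Compound 1 `O=C1c2ccc(OCc3cccc(-c4ccc(C(F)(F)F)cc4F)c3)cc2CN1C1CCCC1` gives only a limit, not a number, in an assay on HEK293 cells for positive allosteric modulation of metabotropic glutamate receptor 2 (Rattus norvegicus), read by thallium flux; on this read-out lower numbers stand for an effect already at smaller amounts and higher numbers for an effect only at larger amounts of compound: compound 1 shows > 5000 nM. That places compound 1 at the limit of > 5000 nM in this assay, at which 1 of the 2 values shown sits. Compound 2 `O=C(O)c1cc(-c2cccc(COc3ccc4c(=O)n(C5CCCC5)sc4c3)c2)ccc1F`, which carries a carboxylic acid on a different core, gives 240 nM in this assay. Compound 3 `O=C(O)c1cc(F)cc(-c2cccc(COc3ccc4c(c3)CN(C3CCCC3)C4=O)c2)c1` keeps the core of compound 1 with one change: 3-carboxy-5-fluorophenyl in place of 2-fluoro-4-(trifluoromethyl)phenyl on an aromatic carbon. Because compound 2 reaches 240 nM, the step of an at least 8.3-fold lower number from compound 1 to compound 3 (0.92 log units; beyond the scatter) is expected to run towards smaller amounts and to exceed the usual scatter. Compound 3 is thus expected to give about 600 nM, between 150 nM and 2500 nM.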

Compound 3, half-maximal effective concentration: 130 nM
Compound 3: middle estimate off by 4.6-fold (0.66 log units), on the high side; measured number below the stated range.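

On the shared core, 3-carboxy-5-fluorophenyl in place of 2-fluoro-4-(trifluoromethyl)phenyl brings an at least 38-fold lower number from compound 1 to compound 3 (1.58 log units; beyond the scatter) in this assay. Compound 2 had shown a carboxylic acid only on a different core, whereas this change shows one on the core of compound 1, with a single place altered. The value of compound 1 is a limit: the limit of > 5000 nM in this assay, at which 1 of the 3 values shown sits.

Going by these compounds, the fluorine and the carboxylic acid change together in this step, so what each contributes remains open. On these data alone, whether a methyl ester, a primary amide or a tetrazole in the same place would give a similar value also remains open.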